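The compounds below may be only part of what the source reports. "The series", "measured", "known", "first", "only" and "open" are said of these compounds alone.

Three compounds have been measured in an assay on isolated protein for binding affinity to Adrenergic receptor alpha-1 (Rattus norvegicus), read by radioligand binding; a higher number here means a weaker inhibitor, a lower number a stronger inhibitor:
compound 1, `COc1ccc2c(c1)C(CCCN1CCN(c3cccc(C(F)(F)F)c3)CC1)CCC2`, 2930 nM;
compound 2, `COc1ccc2c(c1)C(CCCN1CCN(c3ccccn3)CC1)CCC2`, 261 nM;
compound 3, `COc1ccc2c(c1)C(CCCN1CCN(c3cccc(C(F)(F)F)c3)CC1)=CCC2`, 3070 nM.

Compound 2 differs from compound 1 by pyridin-2-yl in place of 3-(trifluoromethyl)phenyl on an amine nitrogen in a ring, and this change gave an 11-fold lower number from compound 1 to compound 2 (1.05 log units; beyond the scatter). The difference between the cores of compound 1 and compound 3 is not broken down here; in this assay compound 1 gives 2930 nM and compound 3 gives 3070 nM, two numbers within the usual scatter of each other. Compound 4, `COc1ccc2c(c1)C(CCCN1CCN(c3ccccn3)CC1)=CCC2`, is not yet measured; it stands to compound 3 as compound 2 stands to compound 1, by the same change, (pyridin-2-yl in place of 3-(trifluoromethyl)phenyl on an amine nitrogen in a ring). For compound 4 the same step is expected again, an 11-fold lower number from compound 3 to compound 4 (1.04 log units; beyond the scatter), resting on compound 1 at 2930 nM and compound 3 at 3070 nM. Compound 4 is therefore estimated at 280 nM, with a likely range from 130 nM to 600 nM.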

Compound 4, half-maximal inhibitory concentration: 152 nM
The estimate for compound 4 lay 1.8-fold (0.27 log units) above the measured number, within the range that was stated.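

In this assay, putting pyridin-2-yl in place of 3-(trifluoromethyl)phenyl gave a 20-fold lower number from compound 3 to compound 4 (1.31 log units; beyond the scatter), and this step agrees with the one seen earlier on the other core: the same change on two cores in this assay, an 11-fold lower number (1.05 log units; beyond the scatter) from compound 1 to compound 2 and a 20-fold lower number (1.31 log units; beyond the scatter) from compound 3 to compound 4, 1.8-fold (0.26 log units) apart, within the scatter of two such steps. The change therefore carried from one core to the other in this pair of cores, with a large step on both. Among the compounds shown here, this does not show that it would carry to any further core, since only two pairs are available, and it does not explain what lies behind the step.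

The compounds shown leave open how other groups on the same amine nitrogen, such as a plain phenyl or a pyrimidin-2-yl, would behave on these cores. They also leave open whether a longer chain to the core would keep the step.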